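A few compounds are considered here, and "the series" means these few. Any claim that something is new, unique, unknown or untested is made for them only; others in the source may bear on it.

The measured compounds and their numbers:

Compound 1, `CC(=O)OC/C1=C/C[C@](C)(CCC=C(C)C)/C=C/[C@@H](OC(=O)C=C(C)C)[C@](C)(O)/C=C/C1=O`, gives 2950 nM.
Compound 2, `CC(=O)OC/C1=C/C[C@](C)(CCC=C(C)C)/C=C/[C@@H](OC(=O)C=C(C)C)[C@](C)(OC(C)=O)/C=C/C1=O`, gives 15100 nM.
Compound 3, `CC(C)=CCC[C@]1(C)/C=C/[C@@H](OC(=O)C=C(C)C)[C@](C)(O)CCC(=O)/C(CO)=C\C1`, reaches only a limit of the assay, > 40000 nM.

These numbers come from a functional assay on A549 cells (Homo sapiens) for antiproliferative activity, read by MTT assay, with a stated time of 48 h; a lower number here means a stronger inhibitor, a higher number a weaker inhibitor. Among the numbers given as numbers, compound 1 stands at the lower one, and its nearest neighbour is compound 2, reached by a 5.1-fold higher number from compound 1 to compound 2 (0.71 log units; beyond the scatter), a change that puts acetyl in place of hydrogen on an oxygen on a saturated carbon. For the measured compounds named here, for compound 3 only a limit is known, (the limit of > 40000 nM in this assay, at which 1 of the 3 values shown sits), so it gives no step to compare.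

Compound 4, `COCOC/C1=C/C[C@](C)(CCC=C(C)C)/C=C/[C@@H](OC(=O)C=C(C)C)[C@](C)(O)/C=C/C1=O`, has not yet been measured. It differs from compound 1 as follows: methoxymethyl in place of acetyl on an oxygen on a saturated carbon. Going by the values given here, the only measured step, that from compound 1 to compound 2, touches a different oxygen, so it bears on this change only as a distant hint that altering groups on these oxygens can move the number by a modest amount. With the group swapped here keeping the same count of heavy atoms and the same single hydrogen-bond acceptor, the expectation for compound 4 is a step near the scatter, a 1.2-fold higher number from compound 1 to compound 4 (0.07 log units; within the scatter). Compound 4 is therefore estimated at 3500 nM, within a range from 1200 nM to 10000 nM.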

Compound 4, half-maximal inhibitory concentration: 2980 nM
Compound 4: the middle estimate sits 1.2-fold (0.07 log units) above what was measured; measured number inside the range.
By their numbers in this assay, from the lowest: compounds 1 and 4 (each within the scatter of the next); then compound 2. At a limit, above all of these: compound 3.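

In this assay, putting methoxymethyl in place of acetyl on an oxygen on a saturated carbon gives a 1.0-fold higher number from compound 1 to compound 4 (0.00 log units; within the scatter), so the two compounds cannot be told apart. For the compounds shown here, the earlier step, a 5.1-fold higher number from compound 1 to compound 2 (0.71 log units; beyond the scatter), concerned a different oxygen, so this is the first reading at this position, and it shows that the number holds with the acetyl carbonyl gone, provided the group that enters has the same count of heavy atoms, as methoxymethyl does. Nothing measured here gives a reason for this result.

This single swap says how one group of the same size compares with acetyl, so it leaves open how far the position can be pushed with something larger or of a different kind, such as a longer chain like butyryl, a benzyl ether, or an amine or a carboxylic acid at the end of the side arm. It also leaves open whether the match between these two groups would hold on cells other than those used here or at other times of exposure.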